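Methyl for fluoro on a weak cytotoxic amide

The compounds below may be only part of what the source reports. "The series", "measured", "known", "first", "only" and "open" are said of these compounds alone.

Of the compounds shown here, two have been tested so far. Compound 1 `Cn1ccc2c(Oc3ccc(NC(=O)c4nn(-c5ccc(Cl)c(C(F)(F)F)c5)ccc4=O)cc3F)ccnc21` is the stronger of the two: in a functional assay on A549 cells (Homo sapiens) for cytotoxicity, read by MTT assay, with a stated time of 72 h (a lower number here means a stronger inhibitor, a higher number a weaker inhibitor), compound 1 gives 17700 nM. Compound 2 `Cc1cc(=O)n(-c2ccc(F)cc2)nc1C(=O)Nc1ccc(Oc2ncnc3[nH]ccc23)cc1` reaches no measurable number at all. In this assay compound 2 gives > 60000 nM, which is a limit of the assay rather than a value. That is where compound 2 stands, at the limit of > 60000 nM in this assay, at which 1 of the 2 values shown sits.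

Compound 3 `Cc1ccc(-n2nc(C(=O)Nc3ccc(Oc4ncnc5[nH]ccc45)cc3)c(C)cc2=O)cc1` differs from compound 2 in one place: methyl in place of fluoro on an aromatic carbon. Within the data shown here, with no measured step of this kind among the two compounds, the expectation for the change from compound 2 to compound 3 is no step beyond the usual scatter, and the step that the limit leaves unreadable from compound 2 to compound 3 is an estimate, not a measurement. Compound 3 is therefore expected to give about 70000 nM in this assay, in a range from 25000 nM to 200000 nM, most likely again reported only as a limit.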

Compound 3, half-maximal inhibitory concentration: 6400 nM
Beside the measured number, compound 3's estimate is 11-fold (1.04 log units) above it, and the stated range ends above it.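

Replacing 4-fluorophenyl with 4-methylphenyl gives an at least 9.3-fold lower number from compound 2 to compound 3 (0.97 log units; beyond the scatter) in this assay, so changing one heavy atom at this position is enough to bring the series from no measurable number to a measured one. This is the first pair shown that differs in only one place, and the finding rests on this single pair and its shared core. Compound 2 has only a limit of the assay, so the step has a floor and no exact size: the limit of > 60000 nM in this assay, at which 1 of the 3 values shown sits.

A hydrogen, a chloro, a methoxy or an amine at this position would show whether methyl itself matters or only the loss of fluoro, and none of these stands among the compounds shown. Going by these compounds, it also stays open whether the same swap would act similarly on the core of compound 1.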